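Notes on replacing the 2-methoxyethyl group of compound 2

The source may hold more compounds than are shown below. What is called first, only, known or untested is meant among the compounds shown, and "the series" means these compounds.

Measured so far in a physicochemical assay for solubility, read by LC-MS, in phosphate buffer, with a stated time of 24 h, at pH 7.4; a higher number here means a more soluble compound, a lower number a less soluble compound
- compound 1 `O=C1c2ccccc2CN1c1cnc(NCc2c(F)ccc3c2CCO3)n2cnnc12` gives 4000 nM
- compound 2 `COCCC(=O)Nc1cnc(NCc2c(F)ccc3c2CCO3)n2cnnc12` gives 980000 nM

Compound 2 has the higher of the two numbers in this assay and stands well above compound 1. The next compound is compound 3 `CN(C)Cc1ccc(C(=O)Nc2cnc(NCc3c(F)ccc4c3CCO4)n3cnnc23)cc1`, which carries one change from compound 2: 4-((dimethylamino)methyl)phenyl in place of 2-methoxyethyl on a carbonyl carbon. In short, 4-((dimethylamino)methyl)phenyl stands in place of 2-methoxyethyl on a carbonyl carbon.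

Among the measured compounds shown here, only one measured step bears on this. In a 250-fold higher number from compound 1 to compound 2 (2.39 log units; beyond the scatter), large and beyond the scatter, a group bearing rings left and a group with no ring entered, and on that step a lower number is expected for compound 3, where a ring enters and a chain leaves. The support is thin: it is a single step, on an aromatic carbon rather than a carbonyl carbon, with different groups. Only part of its size is expected to carry over. The estimated change is an 8.2-fold lower number from compound 2 to compound 3 (0.91 log units; beyond the scatter), a clear drop beyond the scatter. The expected value for compound 3 is 120000 nM (estimated range 20000 nM to 700000 nM)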

Compound 3, solubility: 520000 nM
The estimate for compound 3 lay 4.3-fold (0.64 log units) below the measured number; measured number inside the range.
By their numbers in this assay, from the lowest: compound 1; then compounds 3 and 2 (each within the scatter of the next).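

In this assay, 4-((dimethylamino)methyl)phenyl in place of 2-methoxyethyl on a carbonyl carbon gives a 1.9-fold lower number from compound 2 to compound 3 (0.28 log units; within the scatter) and so leaves compound 2 and compound 3 indistinguishable in this read-out. This position thus takes a group of 10 heavy atoms with a six-membered aromatic ring of carbon only in place of 2-methoxyethyl, which has no ring, with no read-out change beyond the scatter, so the large step of a 250-fold higher number from compound 1 to compound 2 (2.39 log units; beyond the scatter), made on an aromatic carbon, gives no general rule that a ring entering the molecule lowers the number. No measurement shown gives a reason for this result.

Open, going by these compounds, is how much of the result for compound 3 belongs to the phenyl ring and how much to the dimethylamino group on its methyl arm, as the two enter together in this single change. A plain phenyl on the same carbonyl carbon, and a phenyl carrying a carboxylic acid or a longer chain ending in an amine, would separate these parts and show how far this position tolerates other groups.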